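Replacing chloro with formyl in a cytotoxicity comparison

The source may hold more compounds than are shown below. What is called first, only, known or untested is meant among the compounds shown, and "the series" means these compounds.

Among the measured compounds shown here, in a functional assay on MONO-MAC-6 cells (Homo sapiens) for cytotoxicity, read by MTT assay, with a stated time of 24 h (a lower number here means a stronger inhibitor, a higher number a weaker inhibitor), compound 2 (`O=C(Nc1ccc(C(F)(F)F)cc1)c1cc(Cl)ccc1O`) gives 2200 nM as the only exact number available. The larger compound 1 (`C/C(=N\OCC(=O)N[C@H](C(=O)N[C@@H](CCCCN)C(=O)N1CCC[C@H]1C(=O)N[C@@H](CCCCN)C(=O)NCC(N)=O)[C@@H](C)O)c1ccc(NC(=O)c2cc(Br)ccc2O)cc1`) gives > 200000 nM as a limit of the assay and not as a number. Compound 3 (`O=Cc1ccc(O)c(C(=O)Nc2ccc(C(F)(F)F)cc2)c1`) has not yet been measured. It differs from compound 2 by having formyl in place of chloro on an aromatic carbon, para to a hydroxy group (formyl in place of chloro on an aromatic carbon). For the measured compounds named here, no measured pair shows the effect of this exchange, so the expectation in this assay rests on compound 2 at 2200 nM as its single anchor. A modest loss of strength is expected, close to the edge of the usual scatter, and the expected step of a 2.0-fold higher number from compound 2 to compound 3 (0.31 log units; beyond the scatter) is correspondingly small. Compound 3 is estimated at 4500 nM with an expected range from 1500 nM to 14000 nM in this measurement.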

Compound 3, half-maximal inhibitory concentration: 21500 nM
For compound 3 the middle estimate is 4.8-fold (0.68 log units) below the measured one; measured number above the stated range.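

In this assay, the exchange of chloro for formyl on the aromatic carbon para to a hydroxy group now has a measured effect, a step of a 9.8-fold higher number from compound 2 to compound 3 (0.99 log units; beyond the scatter). This position therefore responds to the group it carries: with formyl there, compound 3 is a weaker inhibitor than the chloro compound, yet it still gives a measured number of 21500 nM and not a limit. Nothing in the data shown gives a reason for this step.

A single pair cannot separate what is lost with chloro from what is gained with formyl, and it cannot show whether the step would hold on another core. On these data alone, how a nitrile, a methyl group or a carboxylic acid would behave at this position also remains open.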